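The source may report more compounds than this note shows. Statements on the series, on what has been measured and on what is new or still open speak of the compounds shown alone.

Compound 1 `Nc1ccc(Cl)cc1C1=NN(C(=O)c2ccccc2)CC1`: 17%
Compound 2 `COc1ccc(N)c(C2=NN(C(C)=O)CC2)c1`: 20.4%

In an assay on isolated protein for inhibition of Nitric oxide synthase, inducible (Homo sapiens), with a stated time of 30 min, tested at 1 mM (on this read-out lower numbers stand for less inhibition and higher numbers for more inhibition at the one concentration tested (going by the name of the read-out)), compound 2 gives 20.4%, and compound 1 gives 17%; the two numbers lie within the usual scatter of each other, so neither stands apart. Compound 3 `CCC(=O)N1CCC(c2cc(OC)ccc2N)=N1` differs from compound 2 by methyl in place of hydrogen on a saturated chain carbon bound to a carbonyl carbon. Among the compounds with values here, no step between two measured compounds is available to gauge such a change, so only a small shift, if any beyond the scatter, is expected in this assay. Compound 3 is therefore estimated at 20%, with a range from 8% to 32%. This expected result corresponds to a step of a number 0.4 percentage points lower from compound 2 to compound 3 (within the scatter).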

Compound 3, a percentage reported as inhibition, at one concentration (the size of the read-out at that concentration, not a potency): 20.4%
Estimate against measurement, compound 3: 0.4 percentage points below; low and high end bracket the measured number.
By their numbers in this assay, from the lowest: compounds 1, 2 and 3 (each within the scatter of the next).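

In this assay, within the data shown here, lengthening acetyl to propanoyl gives no change at the digits printed from compound 2 to compound 3 (within the scatter), the first step here between two measured compounds that differ in one place. Methyl in place of hydrogen on a saturated chain carbon bound to a carbonyl carbon therefore leaves this read-out within the usual scatter at the one concentration tested. No measured evidence is available to explain this result. The compounds shown leave open whether a longer chain, such as butanoyl, would also leave the read-out unchanged. They also leave open what an amine or a carboxylic acid on that same carbon would do.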